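Methyl for bromo on compound 3

A few compounds are considered here, and "the series" means these few. Any claim that something is new, unique, unknown or untested is made for them only; others in the source may bear on it.

In a functional assay on P388 cells (Mus musculus) for inhibition (a lower number here means a stronger inhibitor, a higher number a weaker inhibitor), compound 3 `O=C1/C(=C/c2cccc(Br)c2)Cc2ccccc21` gives 21000 nM and compound 1 `O=C1/C(=C/c2cccc(Cl)c2)Cc2ccccc21` gives 26300 nM. Going by the values given here, these are the only two true numbers so far, and they sit level within the scatter. Compound 2 `O=C1/C(=C/c2ccc(Cl)cc2)Cc2ccccc21` reads > 50000 nM, which is a limit of the assay and not a number.

Compound 4 `Cc1cccc(/C=C2\Cc3ccccc3C2=O)c1`, not yet measured, carries methyl in place of bromo on an aromatic carbon. Among the compounds with values here, the one measured step that bears on this swap is a 1.3-fold lower number from compound 1 to compound 3 (0.10 log units; within the scatter), where bromo takes the place of chloro on an aromatic carbon. That single swap of one group for another stayed within the scatter. One step is thin evidence, but it gives no reason to expect a change beyond the scatter in this assay, and it points in no clear direction. The expected step is small, a 1.2-fold higher number from compound 3 to compound 4 (0.08 log units; within the scatter). For compound 4 the estimated value is 25000 nM, with an expected range from 11000 nM to 50000 nM.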

Compound 4, half-maximal inhibitory concentration: 24900 nM
The estimate for compound 4 lay 1.0-fold (0.00 log units) above the measured number; the range from low to high includes it.
By their numbers in this assay, from the lowest: compounds 3, 4 and 1 (each within the scatter of the next). At a limit, above all of these: compound 2.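

In this assay, going by these compounds alone, methyl is the first group on this aromatic carbon, meta to a large group, that is not a halogen. Replacing bromo gives a 1.2-fold higher number from compound 3 to compound 4 (0.07 log units; within the scatter), and replacing chloro gives a 1.1-fold lower number from compound 1 to compound 4 (0.02 log units; within the scatter), so these three compounds show no separation between methyl and either halogen at this position. Compound 2, with chloro at a different ring carbon, stands at a limit of the assay, not at a true number: the limit of > 50000 nM in this assay, at which 1 of the 4 values shown sits.

Going by these compounds, whether a group of another kind at this position, such as an amine, a carboxylic acid or a longer chain, would move the number beyond the scatter remains open. Also open, on these data alone, is how methyl or bromo would read on the ring carbon that carries chloro in compound 2.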